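The source may report more compounds than this note shows. Statements on the series, on what has been measured and on what is new or still open speak of the compounds shown alone.

The measured compounds and their values:

Compound 1, `O=C(O)c1cc(=O)c2ccc(OCCCCCOc3ccccc3)cc2o1`, gives 0.4 ug/mL.
Compound 2, `COc1cccc(OCCCCCOc2ccc3c(=O)cc(C(=O)O)oc3c2)c1`, gives 1.5 ug/mL.
Compound 3, `CCCc1c(OCC(O)COc2ccc3c(=O)cc(C(=O)O)oc3c2CCC)ccc(C(C)=O)c1OC`, gives 45 ug/mL.

All three were tested in a functional assay on ileum (Cavia porcellus) for antagonist activity, with a stated time of 30 s; on this read-out higher numbers stand for weaker inhibition and lower numbers for stronger inhibition. Compound 3 has the highest number of the three, and the difference between its core and that of compound 2 is not broken down here. Between compound 2 and compound 1 the change is hydrogen in place of methoxy on an aromatic carbon, and it produced a 3.8-fold lower number from compound 2 to compound 1 (0.57 log units; beyond the scatter).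

Compound 4, `CCCc1cc(C(C)=O)ccc1OCC(O)COc1ccc2c(=O)cc(C(=O)O)oc2c1CCC`, has not yet been measured. It differs from compound 3 by hydrogen in place of methoxy on an aromatic carbon. This is the same kind of change as that from compound 2 to compound 1, but the surroundings differ: in compound 3 the methoxy sits ortho to a propyl group and ortho to an acetyl group as well as meta to a large group, whereas in compound 2 it is only meta to a large group. Resting on the step from compound 2 to compound 1 in this assay, compound 4 is expected to show a 2.3-fold lower number from compound 3 to compound 4 (0.35 log units; beyond the scatter), a modest lowering that might be smaller given the different neighbours. The estimate for compound 4 is 20 ug/mL, with a range from 8 ug/mL to 50 ug/mL.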

Compound 4, half-maximal inhibitory concentration: 0.15 ug/mL
Compound 4: the middle estimate sits 130-fold (2.12 log units) above what was measured; the measured number lies below the stated range.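

In this assay hydrogen in place of methoxy gave a 300-fold lower number from compound 3 to compound 4 (2.48 log units; beyond the scatter) and so lowered the number on this core as well. Set beside the earlier step, the two results do not agree in size: the same change on two cores in this assay, a 3.8-fold lower number (0.57 log units; beyond the scatter) from compound 2 to compound 1 and a 300-fold lower number (2.48 log units; beyond the scatter) from compound 3 to compound 4, 80-fold (1.90 log units) apart, beyond the scatter of two such steps

The direction of the change carried from one core to the other in these two pairs, but its size did not, so a step read on one core gave no reliable size for the other. Two pairs cannot show which feature of the surroundings goes with the larger step, whether the propyl group, the acetyl group or something else in the core, and they give no cause for the gap.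

The compounds shown leave open whether the large step would survive if a methyl group stood for the propyl group or a nitrile for the acetyl group. They also leave open whether fluorine or an ethoxy group in place of the methoxy would follow the same course on either core.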